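Hydrazide series: phenylethenyl imine in place of tolyl imine

The source may report more compounds than this note shows. Statements on the series, on what has been measured and on what is new or still open speak of the compounds shown alone.

Measured compounds:
compound 1 `Cc1ccc(/C=N/c2ccccc2C(=O)NNc2ccnc3cc(Cl)ccc23)cc1` — 5.31
compound 2 `COc1cc(/C=N/c2ccccc2C(=O)NNc2ccnc3cc(Cl)ccc23)cc(OC)c1OC` — 4.94
compound 3 `O=C(NNc1ccnc2cc(Cl)ccc12)c1ccccc1/N=C/c1ccncc1` — 3.86

In a physicochemical assay for lipophilicity, measured as octanol-water partition (a lower number here means a more polar compound, a higher number a more lipophilic compound), compound 1 stands highest of the three, compound 2 sits lower and compound 3 lower still, both gaps beyond the scatter. Compound 4 `O=C(NNc1ccnc2cc(Cl)ccc12)c1ccccc1/N=C/C=C/c1ccccc1` differs from compound 1 in one place: 2-phenylethenyl in place of 4-methylphenyl on a carbon with a double bond to nitrogen. For the measured compounds named here, the only measured step at this carbon is a number 1.45 log units lower from compound 1 to compound 3 (beyond the scatter), but there a pyridin-4-yl entered; here the entering 2-phenylethenyl keeps a six-membered aromatic ring of carbon only and one double bond outside aromatic rings, so no step of that kind is expected. Compound 4 is therefore expected near 5.3, within 4.8 to 5.8. The expected step of a number 0.01 log units lower from compound 1 to compound 4 (within the scatter) lies within the scatter.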

Compound 4, partition coefficient: 5.54
Estimate against measurement, compound 4: 0.24 log units below; measured number inside the range.
By their numbers in this assay, from the lowest: compound 3; then compound 2; then compounds 1 and 4 (each within the scatter of the next).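

In this assay, 2-phenylethenyl at the carbon with a double bond to nitrogen gives a number 0.23 log units higher from compound 1 to compound 4 (within the scatter), so a double bond outside aromatic rings can enter with 4-methylphenyl leaving and no step beyond the scatter results. The same place gives a number 1.68 log units higher from compound 3 to compound 4 (beyond the scatter), so pyridin-4-yl now stands apart from both carbon-only groups, compound 1 and compound 4. No measured evidence accounts for these steps. Open, from the compounds shown here alone, is how an amine or a carboxylic acid at this place, or a longer chain ending in phenyl, would read in this assay.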